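Chloro to Methoxy on the Arylamino Substituent

The source may report more compounds than this note shows. Statements on the series, on what has been measured and on what is new or still open speak of the compounds shown alone.

The parent of the series, compound 1 `CCCOc1ccc(C(=O)Nc2cccc(C)n2)cc1`, carries a methyl on the shared core and gives 7500 nM in an in vitro assay on HEK-tsA201 cells for antagonist activity at Neuronal acetylcholine receptor; alpha4/beta2 (Homo sapiens), read by fluorescence and calcium flux; a higher number here means a weaker inhibitor, a lower number a stronger inhibitor. Compound 2 `CCCCCNc1cccc(NC(=O)c2ccc(OCCC)cc2)n1` replaces that methyl with pentylamino. In this assay compound 2 reaches only the limit of > 100000 nM. Compound 3 `CCCOc1ccc(C(=O)Nc2cccc(Nc3ccc(Cl)cc3)n2)cc1` carries (4-chlorophenyl)amino in the same position. In this assay compound 3 likewise stops at the limit of > 100000 nM. Both replacements of the methyl are large losses: an at least 13-fold higher number from compound 1 to compound 2 (1.12 log units; beyond the scatter) and an at least 13-fold higher number from compound 1 to compound 3 (1.12 log units; beyond the scatter). The step between the two amino analogues, a step that the two limits leave unreadable from compound 2 to compound 3, is hidden by the limit of > 100000 nM in this assay, at which 2 of the 3 values shown sit.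

Compound 4 `CCCOc1ccc(C(=O)Nc2cccc(Nc3ccc(OC)cc3)n2)cc1` differs from compound 3 in one place: methoxy in place of chloro on an aromatic carbon. Going by the values given here, no measured step varies this part of the structure, so the only bearing evidence is that compound 3 itself sits at the limit and that the swap of pentyl for 4-chlorophenyl, a step that the two limits leave unreadable from compound 2 to compound 3, could not be read. The expected step, a number no higher from compound 3 to compound 4 (the limit leaves the size open), is accordingly one of no readable size, with another limit the likeliest outcome. The estimate for compound 4 in this assay is 100000 nM, within 30000 nM to 300000 nM.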

Compound 4, half-maximal inhibitory concentration: > 100000 nM
Compound 4: a limit, no number; the forecaster's own chance of this, stated with the estimate: 70%; the middle value lies on the limit itself.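

Methoxy in place of chloro on the arylamino group does not bring compound 4 back into the readable range of this assay, so a third substituent at this position gives only a limit. The loss on leaving the methyl now extends to (4-methoxyphenyl)amino, with an at least 13-fold higher number from compound 1 to compound 4 (1.12 log units; beyond the scatter). The steps among compound 2, compound 3 and compound 4 cannot be read, so chloro and methoxy cannot be ranked against each other, nor either aryl group against pentyl, because all three compounds give a limit and not a number: the limit of > 100000 nM in this assay, at which 3 of the 4 values shown sit.

Open, on these data alone, is whether any group joined through nitrogen at this position keeps a measurable value, for example a primary amine or methylamino. Also open, as far as these compounds go, is whether a group without that nitrogen, such as ethyl or a longer carbon chain, stays in the range of compound 1, at 7500 nM.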